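One benzyl change on a compound held at the limit

The compounds below may be only part of what the source reports. "The series", "measured", "known", "first", "only" and "open" are said of these compounds alone.

In an ADME assay on HepG2 cells (Homo sapiens) for cytotoxicity, read by MTT assay, with a stated time of 48 h (a lower number here means a stronger inhibitor, a higher number a weaker inhibitor), compound 1 `CN(C)S(=O)(=O)c1ccccc1-c1ccc2ncnc(Nc3ccc(OCc4cccc(F)c4)c(Cl)c3)c2c1` gives > 15000 nM as a limit of the assay and not a number. Compound 2 `O=S(=O)(c1ccc(-c2ccc3ncnc(Nc4ccc(OCc5ccccc5)c(Cl)c4)c3c2)cc1)N1CCOCC1` gives > 15000 nM as a limit too, so no exact value exists for it. Within the data shown here, its standing is told only by the limit of > 15000 nM in this assay, at which 2 of the 2 values shown sit, and no measured step links any two compounds here.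

The next compound to be tested is compound 3 `O=S(=O)(c1ccc(-c2ccc3ncnc(Nc4ccc(OCc5ccc(C(F)(F)F)c(F)c5)c(Cl)c4)c3c2)cc1)N1CCOCC1` and it differs from compound 2 in one place. On a saturated chain carbon bound to an oxygen on an aromatic ring, 3-fluoro-4-(trifluoromethyl)phenyl stands in place of phenyl (3-fluoro-4-(trifluoromethyl)phenyl in place of phenyl on a saturated chain carbon bound to an oxygen on an aromatic ring). The same difference can be read as benzyl to 3-fluoro-4-(trifluoromethyl)benzyl.

Compound 2 at > 15000 nM is the closest reference, and that limit gives no ground for expecting a change in either direction beyond the usual scatter. The expected step is small (a number no higher from compound 2 to compound 3 (the limit leaves the size open)) and no clear shift in this assay is foreseen. The expected value for compound 3 is 15000 nM within an estimated range from 7000 nM to 30000 nM and the assay may well report only a limit again.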

Compound 3, half-maximal inhibitory concentration: > 15000 nM
Compound 3: no number, only a limit; the forecaster's own chance of this, stated with the estimate: 70%; the middle value lies on the limit itself.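

In this assay compound 3 gives > 15000 nM as a limit and not a number. Compound 2 also stands at a limit, so the size of any step between compound 2 and compound 3 cannot be read. Still open, on these data alone, is how far each compound's true value lies past its limit, and whether changing benzyl to 3-fluoro-4-(trifluoromethyl)benzyl shifts it at all.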